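The source may report more compounds than this note shows. Statements on the series, on what has been measured and on what is new or still open speak of the compounds shown alone.

Of the compounds shown here, two have been measured so far in a functional assay on MCF7 cells (Homo sapiens) for antiproliferative activity, read by CellTiter-Glo, with a stated time of 5 days (a higher number here means a weaker inhibitor, a lower number a stronger inhibitor), and both give low numbers. Compound 1 (`O=C(O)/C=C/c1ccc(/C(=C(\c2ccc(F)cc2Cl)C2CCC2)c2ccc(-c3cn[nH]c3)cc2)cc1`) gives 2.9 nM while compound 2 (`N#Cc1cc(Cl)ccc1/C(=C(\c1ccc(/C=C/C(=O)O)cc1)c1ccc(-c2cn[nH]c2)cc1)C1CCC1`) gives 4.4 nM and these two values lie within the scatter of each other, so compound 2 cannot be ranked against compound 1. Going by the values given here, the one measured step is a 1.5-fold higher number from compound 1 to compound 2 (0.18 log units; within the scatter) with 4-chloro-2-cyanophenyl in place of 2-chloro-4-fluorophenyl on the double-bonded chain carbon that also carries a saturated ring carbon.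

Compound 3 (`O=C(O)/C=C/c1ccc(/C(=C(\c2ccc(C(F)(F)F)cc2Cl)C2CCC2)c2ccc(-c3cn[nH]c3)cc2)cc1`) has not yet been measured. Its difference from compound 2 (2-chloro-4-(trifluoromethyl)phenyl in place of 4-chloro-2-cyanophenyl on a double-bonded chain carbon bound to a double-bonded chain carbon and a saturated ring carbon) lies on that same carbon, where 2-chloro-4-(trifluoromethyl)phenyl takes the place of 4-chloro-2-cyanophenyl. The step from compound 1 to compound 2 is the only one that bears on this change, and it stayed within the scatter. Among the compounds with values here, no measured compound carries trifluoromethyl, so the data do not test that group directly. No step beyond the scatter is therefore expected in this assay in either direction. The expected step is a 1.1-fold lower number from compound 2 to compound 3 (0.04 log units; within the scatter) on this estimate. Compound 3 is estimated at 4 nM with 1.5 nM to 11 nM as the expected range.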

Compound 3, half-maximal inhibitory concentration: 16 nM
Compound 3: middle estimate off by 4.0-fold (0.60 log units), on the low side; measured number outside the range, above it.
By their numbers in this assay, from the lowest: compounds 1 and 2 (each within the scatter of the next); then compound 3.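

In this assay, the earlier pair had left open whether the group on the double-bonded chain carbon bound to a double-bonded chain carbon and a saturated ring carbon mattered at all, and the new result shows that it does: 2-chloro-4-(trifluoromethyl)phenyl in place of 4-chloro-2-cyanophenyl gives a 3.6-fold higher number from compound 2 to compound 3 (0.56 log units; beyond the scatter), a modest step but the first beyond the scatter. The change of trifluoromethyl in place of fluoro on an aromatic carbon gives a 5.5-fold higher number from compound 1 to compound 3 (0.74 log units; beyond the scatter), so a single substituent separates compound 3 from the low numbers of the other two compounds, and the tolerance seen in the first step does not extend to every group at this place. Nothing in the data shown accounts for this rise in the number.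

As far as these compounds go, whether a smaller or differently built group on that aromatic carbon, such as methyl, methoxy or a nitrile, would stay with compound 1 or move towards compound 3 remains open. Also open, from the compounds shown here alone, is whether the same change would give a step of similar size if an amide stood in place of the carboxylic acid of the shared core.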